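The compounds below may be only part of what the source reports. "The series", "measured", "known", "first", "only" and "open" are said of these compounds alone.

Compound 1 `COC(=O)c1cc(-c2cccc(NC(=O)c3ccc(/C=C/C(=O)c4ccc(F)cc4)cc3)c2)on1` was examined for how much of it cells tolerate in an ADME assay on Vero cells (Chlorocebus sabaeus) for cytotoxicity, read by MTT assay, with a stated time of 72 h; a lower number here means that less compound is tolerated, a higher number that more compound is tolerated. In this assay, among the compounds with values here, compound 1 gives only the limit > 20 ug/mL, so it stands on a limit rather than a number, and the one other value shown is a limit as well. Compound 2 `COC(=O)c1cc(-c2cccc(NC(=O)c3ccc(/C=C/C(=O)c4ccc(C)c(F)c4)cc3)c2)on1` carries 3-fluoro-4-methylphenyl in place of 4-fluorophenyl on a carbonyl carbon. In this assay compound 2 gives the limit > 50 ug/mL. The step that the two limits leave unreadable from compound 1 to compound 2 cannot be read because the limit of > 20 ug/mL in this assay, at which 1 of the 2 values shown sits, and the limit of > 50 ug/mL in this assay, at which 1 of the 2 values shown sits, hold both of its ends. Compound 3 `COC(=O)c1cc(-c2cccc(NC(=O)c3ccc(/C=C/C(=O)c4ccc([N+](=O)[O-])cc4)cc3)c2)on1` differs from compound 1 by nitro in place of fluoro on an aromatic carbon. Within the data shown here, no measured step bears on this change, and the two limits give neither a size nor a direction to expect in this assay. Compound 3 is therefore expected to give about 30 ug/mL, within a range from 10 ug/mL to 100 ug/mL. That expectation amounts to a step that the limit leaves unreadable from compound 1 to compound 3.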

Compound 3, half-maximal cytotoxic concentration: > 20 ug/mL
Compound 3 ended at the assay's limit (the forecaster's own chance of this, stated with the estimate: 70%); the middle value lies beyond the limit too.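

In this assay compound 3 gives > 20 ug/mL, a limit and not a number. No step can be read from compound 1 or compound 2 to compound 3, as all three stand on limits. The compounds shown leave open whether nitro in place of fluoro changes tolerance at all, and in which direction.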